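A few compounds are considered here, and "the series" means these few. Any claim that something is new, unique, unknown or untested is made for them only; others in the source may bear on it.

In a functional assay on HT-29 cells (Homo sapiens) for cytotoxicity, read by MTT assay, with a stated time of 24 h (on this read-out higher numbers stand for weaker inhibition and lower numbers for stronger inhibition), compound 1 `Cc1cc(-c2nc3cc(F)ccc3o2)ccc1NC(=O)CCl` gives 25400 nM. Among the compounds with values here, the only other compound with a number in this assay is compound 2 `Cc1cc(-c2nc3ccccc3o2)ccc1NC(=O)CN1CCN(CCCN(C)C)CC1`, which gives 15500 nM; the two numbers lie within the scatter of each other, so nothing separates them, and the two structures differ in more than one place, so no single step can be read from them. Compound 3 `Cc1ccc2oc(-c3ccc(NC(=O)CCl)c(C)c3)nc2c1` has not yet been measured. It differs from compound 1 in one place: methyl in place of fluoro on an aromatic carbon, that is, a methyl in place of a fluoro on an aromatic carbon of a six-membered aromatic ring of carbon only, part of a fused system of two rings. Within the data shown here, no measured pair in this set shows what such an exchange does here, so there is no step to lean on. Since compound 1 sits at 25400 nM and the change leaves the rest of the molecule untouched, the step from compound 1 to compound 3 is expected to be a 1.0-fold lower number from compound 1 to compound 3 (0.01 log units; within the scatter), that is, nothing beyond the usual scatter in either direction. On that basis compound 3 is estimated at 25000 nM, with a range from 8000 nM to 80000 nM.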

Compound 3, half-maximal inhibitory concentration: 13800 nM
Compound 3: middle estimate off by 1.8-fold (0.26 log units), on the high side, within the range that was stated.
By their numbers in this assay, from the lowest: compounds 3, 2 and 1 (each within the scatter of the next).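

Within the data shown here, the exchange of fluoro for methyl on an aromatic carbon of a six-membered aromatic ring of carbon only is the first single change that can be read in this set, and in this assay it gives a 1.8-fold lower number from compound 1 to compound 3 (0.26 log units; within the scatter). At this position, one group of a single heavy atom can therefore stand in for another, neither adding a hydrogen-bond donor or acceptor, with no difference on this read-out that can be told from the scatter, so neither group can be ranked above the other. No measurement shown here offers an explanation for the size of this step.

The compounds shown leave open whether this position responds to anything else, such as an amine, a carboxylic acid, a methoxy group or a longer alkyl chain on the same aromatic carbon. They also leave open whether the exchange of fluoro for methyl would give a similar step on a compound carrying the dimethylaminopropyl-bearing side chain of compound 2.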